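This account rests on a few compounds, and the source may have more. Where it says the series, first, only, none or still open, it means among the compounds named here.

Measured compounds in a functional assay on the whole organism (blood) with Rattus norvegicus as the target, at a dose of 100 mg/kg by the oral route; a lower number here means less inhibition, a higher number more inhibition at the dose given (going by the name of the read-out):

Compound 1, `N#Cc1ccc(OCC(O)CN2CCN(c3cccc(C(F)(F)F)c3)CC2)cc1`, gives 49.7%.
Compound 2, `N#Cc1ccc(OCC(O)CN2CCN(c3ccc(F)cc3)CC2)cc1`, gives 38.6%.
Compound 3, `N#Cc1ccc(OCC(O)CN2CCN(c3cccc(Cl)c3)CC2)cc1`, gives 16.5%.

Compound 3 stands lowest of the three: its nearest neighbour is compound 2, and its furthest is compound 1, both beyond the scatter. The step of a number 33.2 percentage points lower from compound 1 to compound 3 (beyond the scatter) is large, and the step of a number 22.1 percentage points lower from compound 2 to compound 3 (beyond the scatter) is modest; both run downward into compound 3.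

Compound 4 is `COc1ccccc1N1CCN(CC(O)COc2ccc(C#N)cc2)CC1`. It differs from compound 3 in one place: 2-methoxyphenyl in place of 3-chlorophenyl on an amine nitrogen in a ring. Within the data shown here, no measured step exchanges a 3-chlorophenyl for a 2-methoxyphenyl, so the two recorded steps bear on it only indirectly. They show that the other aryl groups on the ring nitrogen, in compound 1 and compound 2, sat well above compound 3, which suggests the 3-chlorophenyl is the low point among the groups seen so far. A moderate upward step is therefore expected in this assay, a number 18.5 percentage points higher from compound 3 to compound 4 (beyond the scatter), though the uncertainty is wide. Compound 4 is estimated at 35%, within a range from 10% to 60%.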

Compound 4, a percentage reported as inhibition, in the whole organism at one dose (the size of the read-out at that dose, not a potency): 33.5%
Compound 4: middle estimate off by 1.5 percentage points, on the high side; the measured number falls inside the stated range.
By their numbers in this assay, from the lowest: compound 3; then compounds 4 and 2 (each within the scatter of the next); then compound 1.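

In this assay, the exchange on the ring nitrogen gives a number 17 percentage points higher from compound 3 to compound 4 (beyond the scatter), so a 2-methoxyphenyl, with its one hydrogen-bond acceptor, lifts the read-out clear of the low value seen with 3-chlorophenyl. The other new step, a number 5.1 percentage points lower from compound 2 to compound 4 (within the scatter), leaves 2-methoxyphenyl and 4-fluorophenyl indistinguishable here. Two aryl groups that differ in both substituent and ring position thus give results that cannot be told apart, and compound 3 remains beyond the scatter below both.

As far as these compounds go, each of these exchanges changes the substituent and its ring position together, so it stays open whether a 3-methoxyphenyl, a 2-chlorophenyl or an unsubstituted phenyl would sit near compound 3 or near compound 4. Why the 3-chlorophenyl gives the low value also stays open, as nothing shown here bears on the cause.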